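Meta iodo on the anilino ring of the urea series

The source may report more compounds than this note shows. Statements on the series, on what has been measured and on what is new or still open speak of the compounds shown alone.

Compound 3 `O=C(Nc1ccccc1)N[C@H]1CC[C@H](Oc2ccc(F)cc2)CC1` is the unsubstituted anilino member of the set. In a functional assay on CRL2813 cells (Homo sapiens) for cytotoxicity, read by sulforhodamine B assay, with a stated time of 5 days (on this read-out higher numbers stand for weaker inhibition and lower numbers for stronger inhibition), compound 3 gives 20000 nM, the highest number among the three measured compounds. The nearest is compound 2 `COC(=O)c1cccc(NC(=O)N[C@H]2CC[C@H](Oc3ccc(F)cc3)CC2)c1`, which in this assay gives 9200 nM; the furthest is compound 1 `O=C(Nc1ccccc1[N+](=O)[O-])N[C@H]1CC[C@H](Oc2ccc(F)cc2)CC1`, which in this assay gives 3500 nM.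

Compound 4 `O=C(Nc1cccc(I)c1)N[C@H]1CC[C@H](Oc2ccc(F)cc2)CC1` differs from compound 3 by iodo in place of hydrogen on an aromatic carbon. Within the data shown here, two measured steps bear on it, both reading in the direction of removing a substituent from the anilino ring: a 5.7-fold higher number from compound 1 to compound 3 (0.76 log units; beyond the scatter) and a 2.2-fold higher number from compound 2 to compound 3 (0.34 log units; beyond the scatter). Reversed, both say that putting a group onto this ring lowered the number, by a modest amount in each case. Neither step involves iodo, and the group entering in compound 4 sits meta to a large group, as does the methoxycarbonyl of compound 2, so the closer guide is the smaller of the two steps.

On that basis compound 4 is expected to give a number below that of compound 3 in this assay, with the step of a 2.5-fold lower number from compound 3 to compound 4 (0.40 log units; beyond the scatter) estimated as modest. The estimate for compound 4 in this assay is 8000 nM, with a range from 3000 nM to 20000 nM.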

Compound 4, half-maximal inhibitory concentration: 5200 nM
Beside the measured number, compound 4's estimate is 1.5-fold (0.19 log units) above it; low and high end bracket the measured number.
By their numbers in this assay, from the lowest: compounds 1, 4 and 2 (each within the scatter of the next, the first and the last beyond it); then compound 3.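

In this assay, among these compounds, iodo, a single heavy atom with no hydrogen-bond donors or acceptors, gives a 3.8-fold lower number from compound 3 to compound 4 (0.59 log units; beyond the scatter), so the lower number on substitution of the anilino ring is not confined to nitro and methoxycarbonyl; among compounds 1 to 4, no substituted member goes against this. Iodo in place of methoxycarbonyl gives a 1.8-fold lower number from compound 2 to compound 4 (0.25 log units; within the scatter), and 3-iodophenyl in place of 2-nitrophenyl gives a 1.5-fold higher number from compound 1 to compound 4 (0.17 log units; within the scatter), so in this assay the data do not separate compound 4 from either compound 2 or compound 1, although these are three quite different substituents. Nothing available offers an explanation for the effect of iodo at this position.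

From the compounds shown here alone, it remains open whether the number tracks the halogen itself, which fluoro, chloro or bromo at the same place on the ring would test, and whether iodo gives a similar step elsewhere on this ring. An amine or a carboxylic acid at the place iodo occupies would show whether the lower number extends to groups of a very different kind.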